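Swapping the pendant aryl group on a fused hexacyclic core

The source may report more compounds than this note shows. Statements on the series, on what has been measured and on what is new or still open speak of the compounds shown alone.

Of the compounds shown here, two built on a shared six-ring core have been measured. In a functional assay on AGS cells (Homo sapiens) for cytotoxicity, read by MTT assay, with a stated time of 48 h (on this read-out lower numbers stand for stronger inhibition and higher numbers for weaker inhibition), compound 1 `Cc1nc2c3ccccc3ccc2c2nc3c(ccc4ccccc43)c(-c3nccnc3N)c12` gives 2260 nM, while compound 2 `Cc1nc2c3ccccc3ccc2c2nc3c(ccc4ccccc43)c(-c3cc([N+](=O)[O-])ccc3N)c12` gives 17800 nM. Going by the values given here, compound 2 therefore stands with the highest number of the two, and the only measured step, a 7.9-fold higher number from compound 1 to compound 2 (0.90 log units; beyond the scatter), shows a modest rise when the pendant aryl group was exchanged.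

Compound 3 `Cc1nc2c3ccccc3ccc2c2nc3c(ccc4ccccc43)c(-c3ccccc3S)c12` is not yet measured. It differs from compound 2 only at the same pendant group: 2-sulfanylphenyl in place of 2-amino-5-nitrophenyl on an aromatic carbon. Among the compounds with values here, the single step that bears on this position is a 7.9-fold higher number from compound 1 to compound 2 (0.90 log units; beyond the scatter), which shows that changing the group attached here moved the number by a modest amount and beyond the scatter. That step, however, involved a different exchange, so its direction does not transfer directly.

Given that compound 2 already holds the highest number and compound 1 shows that another group at this position gives a lower one, compound 3 is expected to land between the two, with a step of a 2.5-fold lower number from compound 2 to compound 3 (0.41 log units; beyond the scatter). The estimate for compound 3 in this assay is 7000 nM, within a range from 1800 nM to 28000 nM.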

Compound 3, half-maximal inhibitory concentration: 4070 nM
The estimate for compound 3 lay 1.7-fold (0.24 log units) above the measured number, and the stated range covers the measured number.
By their numbers in this assay, from the lowest: compounds 1 and 3 (each within the scatter of the next); then compound 2.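

In this assay the exchange of 2-amino-5-nitrophenyl for 2-sulfanylphenyl brings a 4.4-fold lower number from compound 2 to compound 3 (0.64 log units; beyond the scatter) and shows that a six-membered aromatic ring of carbon only at this position does not by itself go with the high number of compound 2, since compound 3 carries such a ring too. The other new step, a 1.8-fold higher number from compound 1 to compound 3 (0.26 log units; within the scatter), leaves compound 1 and compound 3 inseparable, so 3-aminopyrazin-2-yl and 2-sulfanylphenyl read alike here despite their different rings, and compound 2 alone stands apart from them. Nothing available here explains why these groups give these numbers.

The step between compound 2 and compound 3 removes an amine and a nitro group and adds a sulfanyl group all at once, so the shown compounds cannot say which of these parts carries the difference. A plain phenyl ring, or a phenyl ring bearing only an amine or only a nitro group, would separate those parts, and a hydroxyl group or a carboxylic acid in place of the sulfanyl group would show whether sulfur itself matters.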